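Halogen swap on a second core in the series

The compounds below may be only part of what the source reports. "The series", "measured", "known", "first", "only" and "open" are said of these compounds alone.

Compound 1 `Cc1ccccc1OCC(=O)Nc1nc(-c2ccc(Br)cc2)cs1` is the reference; in a functional assay on A549 cells (Homo sapiens) for cytotoxicity, read by MTT assay, with a stated time of 48 h (a higher number here means a weaker inhibitor, a lower number a stronger inhibitor), compound 1 gives 50100 nM. Compound 2 `Cc1ccccc1OCC(=O)Nc1nc(-c2ccc(Cl)cc2)cs1` differs from it by chloro in place of bromo on an aromatic carbon, and in this assay compound 2 gives 64900 nM, a step of a 1.3-fold higher number from compound 1 to compound 2 (0.11 log units; within the scatter). Compound 3 `Cc1ccc(OCC(=O)Nc2nc(-c3ccc(Br)cc3)cs2)cc1` stands on the other core; its difference from compound 1 is 4-methylphenyl in place of 2-methylphenyl on an oxygen on a saturated carbon, and in this assay compound 3 gives 58800 nM, a step of a 1.2-fold higher number from compound 1 to compound 3 (0.07 log units; within the scatter). All three numbers sit within the scatter of one another, so no ranking among them is claimed. Compound 4 `Cc1ccc(OCC(=O)Nc2nc(-c3ccc(Cl)cc3)cs2)cc1` is not yet measured. It differs from compound 3 by chloro in place of bromo on an aromatic carbon, the same change as from compound 1 to compound 2, with the place described in identical words. For compound 4 the expected step in this assay is a 1.2-fold higher number from compound 3 to compound 4 (0.09 log units; within the scatter). This rests on the one earlier occurrence of the change, which gave a 1.3-fold higher number from compound 1 to compound 2 (0.11 log units; within the scatter), a shift within the scatter. Compound 4 is therefore estimated at 72000 nM in this assay, between 45000 nM and 115000 nM.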

Compound 4, half-maximal inhibitory concentration: 45700 nM
The estimate for compound 4 lay 1.6-fold (0.20 log units) above the measured number, within the range that was stated.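

In this assay, chloro in place of bromo on the core of compound 3 gives a 1.3-fold lower number from compound 3 to compound 4 (0.11 log units; within the scatter), and this step does not differ from its earlier occurrence on the core of compound 1: the same change on two cores in this assay, a 1.3-fold higher number (0.11 log units; within the scatter) from compound 1 to compound 2 and a 1.3-fold lower number (0.11 log units; within the scatter) from compound 3 to compound 4, 1.7-fold (0.22 log units) apart, within the scatter of two such steps. Read on the chloro compounds, 4-methylphenyl in place of 2-methylphenyl gives a 1.4-fold lower number from compound 2 to compound 4 (0.15 log units; within the scatter), and this step likewise does not differ from its earlier occurrence on the bromo compounds: the same change on two cores in this assay, a 1.2-fold higher number (0.07 log units; within the scatter) from compound 1 to compound 3 and a 1.4-fold lower number (0.15 log units; within the scatter) from compound 2 to compound 4, 1.7-fold (0.22 log units) apart, within the scatter of two such steps. Both changes therefore carry between the two cores without a difference that can be detected here, but every step lies within the scatter, so the data show neither that either change has an effect on any core nor that the opposite printed directions of the halogen steps are real.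

On these data alone, whether an amine or a carboxylic acid in place of the halogen, or a longer chain in place of the methyl group, would move the number beyond the scatter remains open. Also open, as far as these compounds go, is whether these steps would carry across the two cores outside this assay.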